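Oxadiazole isomer swap and buffer solubility

The source may hold more compounds than are shown below. What is called first, only, known or untested is meant among the compounds shown, and "the series" means these compounds.

Compound 3 `Cc1nc(-c2ccc(N3C(=O)C(O)=C(C(=O)C(C)(C)C)C3c3ccccc3OCCO)cc2)no1` carries a 5-methyl-1,2,4-oxadiazol-3-yl group on an aromatic carbon of the shared core. In a physicochemical assay for solubility, in phosphate buffer, at pH 6.8 (a lower number here means a less soluble compound, a higher number a more soluble compound), compound 3 gives > 50000 nM, which is a limit of the assay and not a number. Compound 1 `CC(C)(C)C(=O)C1=C(O)C(=O)N(c2ccc(-c3ccon3)cc2)C1c1ccccc1OCCO` gives in this assay the value > 50000 nM, again a limit. Compound 2 `Cc1cc(-c2ccc(N3C(=O)C(O)=C(C(=O)C(C)(C)C)C3c3ccccc3OCCO)cc2)on1` gives in this assay the value > 50000 nM, also a limit. (the limit of > 50000 nM in this assay, at which 3 of the 3 values shown sit). The steps among these three, a step that the two limits leave unreadable from compound 1 to compound 2, a step that the two limits leave unreadable from compound 1 to compound 3 and a step that the two limits leave unreadable from compound 2 to compound 3, therefore cannot be sized.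

Compound 4 `Cc1noc(-c2ccc(N3C(=O)C(O)=C(C(=O)C(C)(C)C)C3c3ccccc3OCCO)cc2)n1` differs from compound 3 by 3-methyl-1,2,4-oxadiazol-5-yl in place of 5-methyl-1,2,4-oxadiazol-3-yl on an aromatic carbon; the two have the same atoms, joined differently. Among the measured compounds shown here, of the measured steps, the one from compound 1 to compound 3 and the one from compound 2 to compound 3 bear most closely on this change, as each also exchanges the group at an aromatic carbon, but neither could be read. With every measured value sitting at the same limit, the expected step in this assay from compound 3 to compound 4 is a step that the limit leaves unreadable from compound 3 to compound 4. Compound 4 is accordingly estimated at 80000 nM, with a range from 40000 nM to 200000 nM, and the measurement is expected most likely to return only a limit once more.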

Compound 4, solubility: > 50000 nM
Compound 4: only a limit was reported; the forecaster's own chance of this, stated with the estimate: 85%; the middle value lies beyond the limit too.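

In this assay compound 4 gives > 50000 nM, a limit of the assay and not a number. No step linking compound 4 with compound 1, compound 2 or compound 3 can be read: the limit of > 50000 nM in this assay, at which 4 of the 4 values shown sit.

The compounds shown leave open whether the four groups on the aromatic carbon differ at all in this assay.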